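Extending the Acyl Group: From Compound 1 to Compound 4

The source may hold more compounds than are shown below. What is called first, only, known or untested is meant among the compounds shown, and "the series" means these compounds.

compound 1, `CC(=O)c1ccc(OCCCCOc2cccc(C(=O)O)c2C)c(C)c1O`: "not determined" (no result reported)
compound 2, `Cc1ccc(C(=O)O)cc1OCCCCOc1ccc(C(=O)CC2CCCC2)c(O)c1C`: > 10000 nM
compound 3, `Cc1c(OCCCCOc2ccc(C(=O)O)c(Cl)c2)ccc(C(=O)CC2CCCC2)c1C`: > 10000 nM

In an assay on HEK293 cells for positive allosteric modulation of metabotropic glutamate receptor 3 (Rattus norvegicus), read by thallium flux, with a stated time of 2.5 min (a lower number here means that less compound is needed, a higher number that more compound is needed for the effect), compound 1 has no number; its entry reads "not determined" (no result reported). For compound 2 the outcome in this assay is a limit, > 10000 nM. For compound 3 the outcome in this assay is likewise a limit, > 10000 nM. Compound 1 therefore cannot be placed against the other two, and the only landmark is the limit of > 10000 nM in this assay, at which 2 of the 3 values shown sit.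

Compound 4, `CCCC(=O)c1ccc(OCCCCOc2cccc(C(=O)O)c2C)c(C)c1O`, differs from compound 1 by ethyl in place of hydrogen on a saturated chain carbon bound to a carbonyl carbon. Among the compounds with values here, no measured pair shows this change, so its size and direction in this assay cannot be read from data; any shift is expected to stay modest. Because compound 2 and compound 3 rest at the limit of > 10000 nM in this assay, at which 2 of the 3 values shown sit, weak modulation is anticipated for the series. Compound 4 is estimated at 8000 nM, within 1500 nM to 30000 nM, with a limit a likely outcome.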

Compound 4, half-maximal effective concentration: > 10000 nM
Compound 4 ended at the assay's limit (the forecaster's own chance of this, stated with the estimate: 60%); middle value at least 1.2-fold (0.09 log units) from the limit.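

No step can be read between compound 1 and compound 4 in this assay. The compounds shown leave open what any single change does to the shared core, since the values rest at one mark: the limit of > 10000 nM in this assay, at which 3 of the 4 values shown sit.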